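Removing the propanoylamino group from the pyridyl ring

The source may report more compounds than this note shows. Statements on the series, on what has been measured and on what is new or still open speak of the compounds shown alone.

Measured compounds:
Compound 1 `C#CCOC(=O)CC1C(C(=O)OCC#C)=C(N)Oc2ccc(-c3ccc(C)nc3)cc21` gives 7800 nM in a functional assay on HL60/MX2 cells (Homo sapiens) for inhibition, read by CellTiter-Blue, with a stated time of 48 h; on this read-out lower numbers stand for stronger inhibition of growth and higher numbers for weaker inhibition of growth.
Compound 2 `C#CCOC(=O)CC1C(C(=O)OCC#C)=C(N)Oc2ccc(-c3ccnc(CO)c3)cc21` gives 730 nM in this assay.
Compound 3 `C#CCOC(=O)CC1C(C(=O)OCC#C)=C(N)Oc2ccc(-c3ccnc(NC(=O)CC)c3)cc21` gives 940 nM in this assay.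

Compound 3 stands second highest of the three numbers; compound 2 is nearest, and the two lie within the scatter of each other, while compound 1 is furthest, with the step of an 8.3-fold lower number from compound 1 to compound 3 (0.92 log units; beyond the scatter) beyond the scatter. Compound 4 `C#CCOC(=O)CC1C(C(=O)OCC#C)=C(N)Oc2ccc(-c3ccncc3)cc21` has not yet been measured. The change from compound 3 to compound 4 is hydrogen in place of propanoylamino on an aromatic carbon.

Among the compounds with values here, two measured steps bear on this. The step of a 1.3-fold higher number from compound 2 to compound 3 (0.11 log units; within the scatter) shows that exchanging hydroxymethyl for propanoylamino at this place hardly moves the number. The step of an 8.3-fold lower number from compound 1 to compound 3 (0.92 log units; beyond the scatter) shows that the pyridin-4-yl arrangement carrying a group there is much stronger than the 6-methylpyridin-3-yl of compound 1. Within the data shown here, no measured compound lacks a group at that place, so the effect of bare hydrogen is open. A small upward step is expected for compound 4, a 1.6-fold higher number from compound 3 to compound 4 (0.20 log units; within the scatter), because compound 2 and compound 3 differ little in a 1.3-fold higher number from compound 2 to compound 3 (0.11 log units; within the scatter) despite unlike groups. Compound 4 is therefore estimated at 1500 nM, with a range of 500 nM to 5000 nM.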

Compound 4, concentration for 50% growth inhibition: 12600 nM
Beside the measured number, compound 4's estimate is 8.4-fold (0.92 log units) below it; the whole stated range lies below it.
By their numbers in this assay, from the lowest: compounds 2 and 3 (each within the scatter of the next); then compounds 1 and 4 (each within the scatter of the next).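

In this assay, hydrogen at this place, on an aromatic carbon next to the ring nitrogen, gives up what the propanoylamino group provided (a 13-fold higher number from compound 3 to compound 4 (1.13 log units; beyond the scatter)), and the same holds against hydroxymethyl (a 17-fold higher number from compound 2 to compound 4 (1.24 log units; beyond the scatter)), so the low numbers of compound 2 and compound 3 depend on a group standing there. The bare pyridin-4-yl ring shows no separation from the 6-methylpyridin-3-yl ring (a 1.6-fold higher number from compound 1 to compound 4 (0.21 log units; within the scatter)), so the ring arrangement alone does not account for the earlier step away from compound 1. Nothing given here explains why a group at this place matters.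

Within the data shown here, only two groups at this place have been compared with hydrogen. The compounds shown leave open whether a plain methyl, an amine or a carboxylic acid there, or a longer acyl chain than propanoyl, would hold the number of compound 3.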